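The source may hold more compounds than are shown below. What is called first, only, known or untested is meant among the compounds shown, and "the series" means these compounds.

Measured compounds:
compound 1 `Nc1nc(SCc2ccccc2)c2ncn([C@H]3C[C@H](O)[C@@H](CO)O3)c2n1` with "not determined" (no result reported)
compound 2 `C=CCSc1nc(N)nc2c1ncn2[C@@H]1C[C@H](O)[C@@H](CO)O1` with > 100 uM

In a functional assay on L1210 cells (Mus musculus) for inhibition, read by thymidine incorporation (a higher number here means that more compound is needed for the effect, a lower number that less compound is needed), compound 2 reaches only the limit of > 100 uM, and no number is reported for compound 1. On the numbers shown, compound 2 therefore stands at the limit, which the limit of > 100 uM in this assay, at which 1 of the 2 values shown sits, describes, with no single value beside it. Compound 3 `C=CCSc1nc(N)nc2c1ncn2[C@H]1C[C@H](O)[C@@H](CO)O1` differs from compound 2 in the two compounds have the same atoms and bonds and differ only in configuration as drawn: 1 of 3 stereo elements differ; a stereocentre at a saturated ring carbon is drawn S in compound 2 and R in compound 3. With no measured step for a change of this kind among these compounds, no step beyond the scatter can be expected with confidence in this assay. Compound 3 is estimated at 100 uM (range 10 uM to 300 uM), a step of a number no higher from compound 2 to compound 3 (the limit leaves the size open) that is expected to be near none.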

Compound 3, concentration for half-maximal effect: 5.5 uM
Estimate against measurement, compound 3: 18-fold (1.26 log units) above, and the stated range ends above it.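

Drawing the stereocentre at a saturated ring carbon R rather than S gives, in this assay, an at least 18-fold lower number from compound 2 to compound 3 (1.25 log units; beyond the scatter). Within the data shown here, the value of compound 2, > 100 uM, is a limit of the assay, so the real size of the step stays open, but this configuration now clearly matters in a way the earlier compounds could not show. The step belongs to that single centre: the fact that compounds 2 and 3 differ only in the configuration as drawn

Compound 1 gives "not determined" (no result reported), so it offers no comparison. On these data alone, whether this configuration keeps its effect with an amine or a longer chain in place of the sulfur-bound chain remains open.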